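Series notes: tertiary alcohol at the triazole substituent

A few compounds are considered here, and "the series" means these few. Any claim that something is new, unique, unknown or untested is made for them only; others in the source may bear on it.

Three compounds share one core and differ only in the group on the triazole carbon. Compound 1 `OCc1cn(CCNc2nonc2/C(=N/O)Nc2ccc(F)c(Br)c2)nn1` gives 794 nM in an assay on isolated protein for inhibition of Indoleamine 2,3-dioxygenase 2 (Homo sapiens); a higher number here means a weaker inhibitor, a lower number a stronger inhibitor. Compound 2 `CCCCc1cn(CCNc2nonc2/C(=N/O)Nc2ccc(F)c(Br)c2)nn1` gives 830 nM, the highest of the three numbers, with a 1.0-fold higher number from compound 1 to compound 2 (0.02 log units; within the scatter) lying within the scatter. Compound 3 `CC(O)c1cn(CCNc2nonc2/C(=N/O)Nc2ccc(F)c(Br)c2)nn1` gives 362 nM, reached by a 2.3-fold lower number from compound 2 to compound 3 (0.36 log units; beyond the scatter) and by a 2.2-fold lower number from compound 1 to compound 3 (0.34 log units; beyond the scatter).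

Compound 4 `CC(C)CC(C)(O)c1cn(CCNc2nonc2/C(=N/O)Nc2ccc(F)c(Br)c2)nn1` is to be measured. Its change from compound 2 is 1-hydroxy-1,3-dimethylbutyl in place of butyl on an aromatic carbon. The step from compound 2 to compound 3 bears most directly, and the step from compound 1 to compound 3 shows that adding a methyl on the hydroxylated carbon lowered the number; both were modest. A modest lowering is therefore expected, a 2.0-fold lower number from compound 2 to compound 4 (0.30 log units; within the scatter), so compound 4 is estimated at 420 nM, within 200 nM to 900 nM.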

Compound 4, half-maximal inhibitory concentration: 689 nM
The estimate for compound 4 lay 1.6-fold (0.21 log units) below the measured number; low and high end bracket the measured number.
By their numbers in this assay, from the lowest: compounds 3, 4, 1 and 2 (each within the scatter of the next, the first and the last beyond it).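

The 1-hydroxy-1,3-dimethylbutyl group does not separate from butyl in this assay, with a 1.2-fold lower number from compound 2 to compound 4 (0.08 log units; within the scatter), or from hydroxymethyl, with a 1.2-fold lower number from compound 1 to compound 4 (0.06 log units; within the scatter). Against compound 3 it also stays inside the scatter, with a 1.9-fold higher number from compound 3 to compound 4 (0.28 log units; within the scatter), so at this position a tertiary alcohol with a branched chain gives no readable change from any of the earlier groups. No data on hand explain this result. On these data alone, whether an amine or a carboxylic acid at this position would move the number beyond the scatter remains open.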